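Demethylation at the Ether Oxygen of a Limit-Bound Ligand

The source may report more compounds than this note shows. Statements on the series, on what has been measured and on what is new or still open speak of the compounds shown alone.

Compound 1 `CO[C@H]1CC=C2CCN(C)[C@H]2C1`: 100000 nM
Compound 2 `CO[C@H]1CC=C2CCN[C@H]2C1`: > 300000 nM

In an assay on HEK293 cells for displacement of a labelled ligand from Neuronal acetylcholine receptor; alpha4/beta4 (Rattus norvegicus), with a stated time of 4 h (a lower number here means a stronger inhibitor, a higher number a weaker inhibitor), compound 1 gives 100000 nM. Compound 2 yields only > 300000 nM, which is a limit of the assay rather than a number, as recorded by the limit of > 300000 nM in this assay, at which 1 of the 2 values shown sits. Within the data shown here, the sole measured step, an at least 3.0-fold higher number from compound 1 to compound 2 (0.47 log units; beyond the scatter), concerns hydrogen in place of methyl on an amine nitrogen in a ring. Compound 3 `O[C@H]1CC=C2CCN[C@H]2C1` differs from compound 2 by hydrogen in place of methyl on an oxygen on a saturated carbon, or, cut one bond further out, methoxy to hydroxy. Among the measured compounds shown here, no measured step touches this position, and compound 2 already stands at the limit, so the step from compound 2 to compound 3 is expected to be a number no higher from compound 2 to compound 3 (the limit leaves the size open), none beyond the scatter. Compound 3 is therefore estimated at 300000 nM, between 100000 nM and 1000000 nM, most probably reported again as a limit only.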

Compound 3, inhibition constant: > 300000 nM
Compound 3: a limit, no number; the forecaster's own chance of this, stated with the estimate: 80%; the middle value sits exactly at the limit.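

Compound 3 gives > 300000 nM, a limit and not a number, and compound 2 is also held at a limit, so no step can be read between them. The compounds shown leave open what size of change methoxy to hydroxy brings.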